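Swapping a Benzyl Ether for a Methoxymethyl Ether

This account rests on a few compounds, and the source may have more. Where it says the series, first, only, none or still open, it means among the compounds named here.

Compound 1 `CCOc1cc(C(C)(C)C)ccc1C/N=C(\S)NCc1ccc(NS(C)(=O)=O)cc1` and compound 2 `CC(C)(C)c1ccc(C/N=C(\S)NCc2ccc(NS(C)(=O)=O)cc2)c(OCc2ccccc2)c1` share a common core and differ only at a saturated chain carbon bound to an oxygen on an aromatic ring. In a functional assay for inhibition of Vanilloid receptor (Rattus norvegicus) (on this read-out lower numbers stand for stronger inhibition and higher numbers for weaker inhibition), compound 1 gives 1100 nM, while compound 2 gives 770 nM. The step of a 1.4-fold lower number from compound 1 to compound 2 (0.15 log units; within the scatter) is within the scatter, so the two measured compounds stand alongside each other, and compound 2 cannot be singled out as the more potent of the pair.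

Compound 3 `COCOc1cc(C(C)(C)C)ccc1C/N=C(\S)NCc1ccc(NS(C)(=O)=O)cc1` has not yet been measured. It differs from compound 2 by methoxy in place of phenyl on a saturated chain carbon bound to an oxygen on an aromatic ring. Going by the values given here, the only measured step that bears on this position is a 1.4-fold lower number from compound 1 to compound 2 (0.15 log units; within the scatter), a change from methyl to phenyl at the same saturated chain carbon, which did not move the number beyond the scatter. Replacing phenyl with methoxy at that spot therefore gives no ground to expect a shift in this assay in either direction. The expected step of a 1.3-fold higher number from compound 2 to compound 3 (0.11 log units; within the scatter) is within the scatter. Compound 3 is therefore estimated at 1000 nM in this assay, with a range from 400 nM to 2500 nM.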

Compound 3, half-maximal inhibitory concentration: 500 nM
Beside the measured number, compound 3's estimate is 2.0-fold (0.30 log units) above it, and the stated range covers the measured number.
By their numbers in this assay, from the lowest: compounds 3, 2 and 1 (each within the scatter of the next, the first and the last beyond it).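

In this assay, going by these compounds alone, the step of a 2.2-fold lower number from compound 1 to compound 3 (0.34 log units; beyond the scatter) is the first at this position to pass the scatter, though only modestly, so methoxy in place of methyl on the saturated chain carbon bound to an oxygen on an aromatic ring does separate two compounds. The step of a 1.5-fold lower number from compound 2 to compound 3 (0.19 log units; within the scatter) stays within the scatter, so compound 2 and compound 3 stand alongside each other even though a phenyl of 6 heavy atoms gives way to a methoxy of 2 heavy atoms with no ring, and compound 2 also stands within the scatter of compound 1. Nothing available explains why methoxy and methyl part at this position.

The compounds shown leave open whether the separation belongs to the oxygen of the methoxy group in particular or would also appear with another group on that carbon, such as an amine, a hydroxyl or a carboxylic acid. They also leave open whether a longer chain, such as methoxyethyl in place of methoxymethyl, would hold, widen or lose the step seen here.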